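Dropping the para-fluoro: does the halogen matter at all?

This account rests on a few compounds, and the source may have more. Where it says the series, first, only, none or still open, it means among the compounds named here.

Of the compounds shown here, three sharing one core have been tested in a functional assay on the whole organism (strain Wistar albino) for inhibition, with Rattus norvegicus as the target, read by paw edema, with stated times of 30 min and 3 h, at a dose of 50 mg/kg by the oral route (a lower number here means less inhibition, a higher number more inhibition at the dose given (going by the name of the read-out)), differing only in the halogen on the pendant phenyl ring. Compound 1 `NS(=O)(=O)c1ccc2nc(-n3nc(C(F)(F)F)cc3-c3ccc(Br)cc3)sc2c1` gives 60%. Compound 2 `NS(=O)(=O)c1ccc2nc(-n3nc(C(F)(F)F)cc3-c3ccc(Cl)cc3)sc2c1` gives 61%, and compound 3 `NS(=O)(=O)c1ccc2nc(-n3nc(C(F)(F)F)cc3-c3ccc(F)cc3)sc2c1` gives 64%. The steps between them, a number 1 percentage points higher from compound 1 to compound 2 (within the scatter), a number 4 percentage points higher from compound 1 to compound 3 (within the scatter) and a number 3 percentage points higher from compound 2 to compound 3 (within the scatter), are all within the scatter, so none of the three halogens stands apart from the others; compound 3 has the top number of the three only by a margin that the scatter covers.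

Compound 4 `NS(=O)(=O)c1ccc2nc(-n3nc(C(F)(F)F)cc3-c3ccccc3)sc2c1` is the next compound. It differs from compound 3 by hydrogen in place of fluoro on an aromatic carbon. Among the compounds with values here, the steps that bear on this change are the three halogen swaps above, each small. Within the data shown here, a halogen of any size gave the same result, which suggests that removing the halogen altogether will also change little, though no measured step shows a bare phenyl ring. The expected step is therefore a number 3 percentage points lower from compound 3 to compound 4 (within the scatter), not beyond the scatter. Compound 4 is estimated at 61% in this assay, with a range from 50% to 71%.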

Compound 4, a percentage reported as inhibition, in the whole organism at one dose (the size of the read-out at that dose, not a potency): 54%
Estimate against measurement, compound 4: 7 percentage points above; the measured number falls inside the stated range.
By their numbers in this assay, from the lowest: compounds 4, 1, 2 and 3 (each within the scatter of the next).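

In this assay, the position para to a large group can now be read with hydrogen as well as with three halogens. Going from 4-fluorophenyl to phenyl gives the step (a number 10 percentage points lower from compound 3 to compound 4 (within the scatter)), and the matching steps from the other two halogens are (a number 7 percentage points lower from compound 2 to compound 4 (within the scatter)) and (a number 6 percentage points lower from compound 1 to compound 4 (within the scatter)). These steps are each larger than any of the swaps between halogens, yet all of them remain within the scatter, so the bare phenyl ring of compound 4 does not stand apart from the halogen-bearing rings, and no halogen at this position is shown to be needed for the inhibition seen at this dose. No measurement is available that would account for where these numbers fall.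

The compounds shown carry only hydrogen or a halogen at this position, so what an amine, a carboxylic acid or a longer alkyl chain would do there stays open. As far as these compounds go, the trifluoromethyl group and the sulfonamide are the same in all four compounds, so what each contributes to the inhibition also remains open.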